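The compounds below may be only part of what the source reports. "The series", "measured", "known", "first", "only" and "open" are said of these compounds alone.

In a functional assay on MCF7 cells (Homo sapiens) for antiproliferative activity, read by MTT assay, with a stated time of 24 h (on this read-out lower numbers stand for stronger inhibition and higher numbers for weaker inhibition), compound 3 `O=S(=O)(c1ccc(F)cc1)n1c(-c2cn(-c3ccccc3)nc2-c2ccc(C(F)(F)F)cc2)nc2ccccc21` gives 3120 nM. This lies within the scatter of compound 1 `Cc1ccc(-c2nn(-c3ccccc3)cc2-c2nc3ccccc3n2S(=O)(=O)c2ccc(C(F)(F)F)cc2)cc1`, which gives 2340 nM, while compound 2 `O=S(=O)(c1ccccc1)n1c(-c2cn(-c3ccccc3)nc2-c2ccc(C(F)(F)F)cc2)nc2ccccc21` gives a clearly lower 630 nM. The next structure, compound 4 `O=S(=O)(c1ccc(C(F)(F)F)cc1)n1c(-c2cn(-c3ccccc3)nc2-c2ccc(C(F)(F)F)cc2)nc2ccccc21`, has trifluoromethyl in place of fluoro on an aromatic carbon, para to a large group (trifluoromethyl in place of fluoro on an aromatic carbon).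

Among the compounds with values here, only one measured step bears directly on this change. Fluoro in place of hydrogen on an aromatic carbon gave a 5.0-fold higher number from compound 2 to compound 3 (0.69 log units; beyond the scatter), a modest step beyond the scatter. Within the data shown here, that step shows this position can respond to substitution, but no measured compound compares fluoro with trifluoromethyl here. Compound 1 also carries a 4-(trifluoromethyl)phenyl on its sulfonyl group, though it differs from compound 4 elsewhere, and its value sits close to that of compound 3. A step within the scatter, with no firm direction, therefore seems most likely.

The expected step is small: a 1.2-fold lower number from compound 3 to compound 4 (0.10 log units; within the scatter). For compound 4 the estimated value is 2500 nM, with an expected range of 1000 nM to 6000 nM.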

Compound 4, half-maximal inhibitory concentration: 1240 nM
The estimate for compound 4 lay 2.0-fold (0.30 log units) above the measured number; low and high end bracket the measured number.
By their numbers in this assay, from the lowest: compounds 2, 4, 1 and 3 (each within the scatter of the next, the first and the last beyond it).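

Trifluoromethyl and fluoro can now be compared directly at this position on the sulfonyl-bound ring, and the choice between them matters: the change gives a 2.5-fold lower number from compound 3 to compound 4 (0.40 log units; beyond the scatter). Trifluoromethyl in place of hydrogen at the same position gives a 2.0-fold higher number from compound 2 to compound 4 (0.29 log units; within the scatter), so these two cannot be told apart, whereas fluoro stood clearly apart from hydrogen; the numbers therefore do not climb steadily as the group grows from hydrogen to fluoro to trifluoromethyl. Elsewhere in the molecule, trifluoromethyl in place of methyl gives a 1.9-fold lower number from compound 1 to compound 4 (0.28 log units; within the scatter), another step that does not separate the two compounds.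

Nothing measured here gives a reason for this uneven pattern. From the compounds shown here alone, whether an amine, a carboxylic acid or a methoxy group at this position would stay close to hydrogen and trifluoromethyl or stand apart as fluoro does remains open.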